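The source may report more compounds than this note shows. Statements on the series, on what has been measured and on what is new or still open speak of the compounds shown alone.

Compound 2 `C=C1C(=O)[C@]23C[C@@]1(O)CC[C@H]2c1ccc(O)c(C)c1[C@@H]3Cn1cc(-c2ccc(C)cc2)nn1` gives in a functional assay on HL-60 cells (Homo sapiens) for cytotoxicity, read by MTT assay, with a stated time of 4 days (on this read-out lower numbers stand for stronger inhibition and higher numbers for weaker inhibition), a value of 830 nM. Compound 1 `C=C1C(=O)[C@]23C[C@@]1(O)CC[C@H]2c1ccc(OS(=O)(=O)c2ccc(C)cc2)c(C)c1[C@@H]3Cn1cc(-c2ccc(Br)cc2)nn1` differs from compound 2 in two places; in this assay compound 1 gives a value of 1020 nM. These two numbers lie within the scatter of each other, so the pair shows no separation. Compound 3 `C=C1C(=O)[C@]23C[C@@]1(O)CC[C@H]2c1ccc(OS(=O)(=O)c2ccc(C)cc2)c(C)c1[C@@H]3Cn1cc(-c2ccc(C)cc2)nn1` carries (4-methylphenyl)sulfonyl in place of hydrogen on an oxygen on an aromatic ring. Among the compounds with values here, no single-change step has been measured for this substitution; since the two values at hand sit within the scatter, no shift beyond the scatter is expected here. The expected step is a 1.1-fold higher number from compound 2 to compound 3 (0.06 log units; within the scatter). Compound 3 is therefore expected in this assay at 950 nM, within a range from 500 nM to 1800 nM.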

Compound 3, half-maximal inhibitory concentration: 1110 nM
Compound 3: the middle estimate sits 1.2-fold (0.07 log units) below what was measured, and the stated range covers the measured number.
By their numbers in this assay, from the lowest: compounds 2, 1 and 3 (each within the scatter of the next).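

In this assay the change from hydroxy to ((4-methylphenyl)sulfonyl)oxy gives a 1.3-fold higher number from compound 2 to compound 3 (0.13 log units; within the scatter) and so no shift beyond the scatter at this oxygen on an aromatic ring. With the (4-methylphenyl)sulfonyl kept, methyl in place of bromo on an aromatic carbon gives a 1.1-fold higher number from compound 1 to compound 3 (0.04 log units; within the scatter) and likewise no separation. No measurement at hand bears on the reason for these small steps.

Still open, going by these compounds, is whether an amine or a carboxylic acid on this oxygen would move the number beyond the scatter. Also open, on these data alone, is whether a longer chain in place of the methyl on the aromatic carbon would do so.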